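Chain extension on the ester tail of a shared core

A few compounds are considered here, and "the series" means these few. Any claim that something is new, unique, unknown or untested is made for them only; others in the source may bear on it.

The series keeps one core and lengthens the alkyl chain of the ester. Compound 1 is `CCCCCCCCCOC(=O)CCC(=O)N1CCN(CCCOc2cc3c(Nc4ccc(F)c(Cl)c4)ncnc3cc2OC)CC1`; compound 2 is `CCCCCCCCCCOC(=O)CCC(=O)N1CCN(CCCOc2cc3c(Nc4ccc(F)c(Cl)c4)ncnc3cc2OC)CC1`; compound 3 is `CCCCCCCCCCCCOC(=O)CCC(=O)N1CCN(CCCOc2cc3c(Nc4ccc(F)c(Cl)c4)ncnc3cc2OC)CC1`; compound 4, not yet measured, is `CCCCCCCCCCCCCOC(=O)CCC(=O)N1CCN(CCCOc2cc3c(Nc4ccc(F)c(Cl)c4)ncnc3cc2OC)CC1`.

In a functional assay on A549 cells (Homo sapiens) for cytotoxicity, read by MTT assay, with a stated time of 24 h, tested at 80 uM (a lower number here means a stronger effect, a higher number a weaker effect of the compound at the concentration tested), compound 1 gives 7.8%. Compound 2 gives 2% in this assay, and compound 3 gives 2.3%. The step of a number 5.8 percentage points lower from compound 1 to compound 2 (within the scatter) and the step of a number 5.5 percentage points lower from compound 1 to compound 3 (within the scatter) are both within the scatter, as is a number 0.3 percentage points higher from compound 2 to compound 3 (within the scatter). No ordering among the three can be read from these numbers.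

The change from compound 1 to compound 2 is methyl in place of hydrogen on a saturated chain carbon, nine bonds along the chain from an oxygen next to a carbonyl group. The change from compound 3 to compound 4 is methyl in place of hydrogen on a saturated chain carbon, ten or more bonds along the chain from an oxygen next to a carbonyl group. These are the same kind of change, but they sit at different places along the chain, as the two descriptions show. The two cores differ by propyl in place of hydrogen on a saturated chain carbon, nine bonds along the chain from an oxygen next to a carbonyl group.

The earlier step of this kind, a number 5.8 percentage points lower from compound 1 to compound 2 (within the scatter), stayed within the scatter, and all three measured values sit low and close together. The step from compound 3 to compound 4 in this assay is therefore expected to be small, about a number 0.7 percentage points higher from compound 3 to compound 4 (within the scatter), resting on compound 3 giving 2.3% and on the earlier step of a number 5.8 percentage points lower from compound 1 to compound 2 (within the scatter). Compound 4 is expected to give about 3% in this assay, plausibly between 0% and 10%.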

Compound 4, a percentage reported as activity, at one concentration (the size of the read-out at that concentration, not a potency): 6.8%
The estimate for compound 4 lay 3.8 percentage points below the measured number; measured number inside the range.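

In this assay the new steps are a number 4.5 percentage points higher from compound 3 to compound 4 (within the scatter), a number 4.8 percentage points higher from compound 2 to compound 4 (within the scatter) and a number 1 percentage points lower from compound 1 to compound 4 (within the scatter), so compound 4 cannot be ordered against compound 1, compound 2 or compound 3. Set beside the earlier step, the methyl change shows no difference between the two cores, but with both steps inside the scatter, this gives no measurable effect that could be said to carry over: the same change on two cores in this assay, a number 5.8 percentage points lower (within the scatter) from compound 1 to compound 2 and a number 4.5 percentage points higher (within the scatter) from compound 3 to compound 4, 10.3 percentage points apart, within the scatter of two such steps. The propyl change reads the same way, showing no detectable dependence on the core without showing that the change acts equally on both: the same change on two cores in this assay, a number 5.5 percentage points lower (within the scatter) from compound 1 to compound 3 and a number 4.8 percentage points higher (within the scatter) from compound 2 to compound 4, 10.3 percentage points apart, within the scatter of two such steps.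

The compounds shown leave open whether a shorter chain, a phenyl ring, an amine or a carboxylic acid at the end of the ester tail would move the read-out away from the narrow range of these four compounds. They also leave open whether these four chains would separate from one another at a lower test concentration, where the read-out might be less crowded at the low end.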